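The compounds below may be only part of what the source reports. "The series", "measured", "known", "first", "only" and "open" are said of these compounds alone.

In a functional assay on NCI-H460 cells (Homo sapiens) for cytotoxicity, read by MTT assay, with a stated time of 72 h (on this read-out higher numbers stand for weaker inhibition and lower numbers for stronger inhibition), compound 1 `CN(C)CCNc1nc(-c2ccc(NC(=O)Nc3ccc(Cl)cc3)cc2)nc2ccsc12` gives 130 nM. Compound 3 `CN(C)CCNc1nc(-c2ccc(NC(=O)Nc3ccccc3Cl)cc2)nc2ccsc12` differs from it by 2-chlorophenyl in place of 4-chlorophenyl on an amide-type nitrogen, and in this assay compound 3 gives 230 nM, which is a 1.8-fold higher number from compound 1 to compound 3 (0.25 log units; within the scatter). Compound 2 `CN(C)CCNc1nc(-c2ccc(NC(=O)Nc3ccc(Cl)cc3)cc2)nc2c(Cl)c(Cl)sc12` rests on a second core; the difference between the two cores is not broken down here. In this assay compound 2 gives 300 nM, the highest of the three numbers, though only the gap to compound 1 lies beyond the scatter. Compound 4 `CN(C)CCNc1nc(-c2ccc(NC(=O)Nc3ccccc3Cl)cc2)nc2c(Cl)c(Cl)sc12` has not yet been measured in this assay. It differs from compound 2 by 2-chlorophenyl in place of 4-chlorophenyl on an amide-type nitrogen, the same change that separates compound 1 from compound 3 at the same kind of place. Compound 4 is therefore expected to show a 1.7-fold higher number from compound 2 to compound 4 (0.22 log units; within the scatter), an expectation that rests on the measured step of a 1.8-fold higher number from compound 1 to compound 3 (0.25 log units; within the scatter). In this assay compound 4 is estimated at 500 nM, with a likely range from 250 nM to 1000 nM.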

Compound 4, half-maximal inhibitory concentration: 440 nM
The estimate for compound 4 lay 1.1-fold (0.06 log units) above the measured number; the measured number falls inside the stated range.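

In this assay, putting 2-chlorophenyl in place of 4-chlorophenyl on the amide-type nitrogen gives a 1.5-fold higher number from compound 2 to compound 4 (0.17 log units; within the scatter). Set beside the earlier step, the change carries from the core of compound 1 to the core of compound 2 with no difference that can be told apart: the same change on two cores in this assay, a 1.8-fold higher number (0.25 log units; within the scatter) from compound 1 to compound 3 and a 1.5-fold higher number (0.17 log units; within the scatter) from compound 2 to compound 4, 1.2-fold (0.08 log units) apart, within the scatter of two such steps. This shows agreement on these two cores only; as each step lies within the scatter, it does not show that the change itself shifts the number, and two cores make no rule for others in the series.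

The compounds shown leave open what a methoxy or trifluoromethyl group would do in place of the chlorine on the phenyl ring. They also leave open what a morpholine or a longer chain would do in place of the dimethylaminoethyl chain.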